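Swapping one methyl for hydrogen in a weak compound

The source may report more compounds than this note shows. Statements on the series, on what has been measured and on what is new or still open speak of the compounds shown alone.

In a functional assay on MDA-MB-231 cells (Homo sapiens) for antiproliferative activity, read by MTT assay (on this read-out lower numbers stand for stronger inhibition and higher numbers for weaker inhibition), compound 2 `CCCC/C=C\CCCCCCCCCc1cc(=O)c2c(O)c(C)c(OCOC)c(C)c2o1` shows > 87000 nM and that is a limit of the assay, not a number. Compound 1 `CCCC/C=C\CCCCCCCCCc1cc(=O)c2c(O)cc(O)c(C)c2o1` gives a true number of 6790 nM on the same read-out. The edit hydrogen in place of methyl on an aromatic carbon puts hydrogen in place of methyl on an aromatic carbon, and it turns compound 2 into compound 3 `CCCC/C=C\CCCCCCCCCc1cc(=O)c2c(O)cc(OCOC)c(C)c2o1`. A modest gain in strength is expected in this assay though the result may again be only a limit. The expected step of an at least 2.1-fold lower number from compound 2 to compound 3 (0.33 log units; beyond the scatter) would stay moderate. Compound 3 is estimated at 40000 nM (range 12000 nM to 90000 nM).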

Compound 3, half-maximal inhibitory concentration: > 87000 nM
Compound 3: only a limit was reported; the forecaster's own chance of this, stated with the estimate: 45%; middle value at least 2.1-fold (0.33 log units) from the limit.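

Removing the methyl from this aromatic carbon gives no measurable number, so the step between compound 2 and compound 3 cannot be read, and both values are only limits of the assay: the limit of > 87000 nM in this assay, at which 2 of the 3 values shown sit.

With hydrogen on this carbon, compound 3 allows a single-change comparison at the oxygen, where methoxymethyl in place of hydrogen gives an at least 12-fold higher number from compound 1 to compound 3 (1.10 log units; beyond the scatter). The group on that oxygen therefore matters strongly in this pair.

On these data alone, whether the methyl itself changes activity stays open. So does how an amine or fluorine on this carbon would read.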